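From 4-bromo-3-hydroxyphenyl to 1H-indol-3-yl on the chain

The compounds below may be only part of what the source reports. "The series", "measured", "known", "first", "only" and "open" are said of these compounds alone.

Of the compounds shown here, three have so far been tested in a functional assay on DU-145 cells (Homo sapiens) for inhibition, read by trypan blue exclusion, with a stated time of 96 h; a higher number here means a weaker inhibitor of growth, a lower number a stronger inhibitor of growth. Compound 3 (`O=C(/C(=C\c1ccc(Br)c(O)c1)Sc1ccc(Br)cc1)c1ccc(Br)cc1`) gives 1000 nM, level with compound 2 (`O=C(/C(=C\c1ccc(Br)cc1)Sc1ccc(Br)cc1)c1ccc(Br)cc1`) at 1000 nM, and these two share the lowest number of the three. Compound 1 (`Cc1ccc(S/C(=C/c2c[nH]c3ccccc23)C(=O)c2ccc(Br)cc2)cc1`) stands higher at 10000 nM, which makes it the weaker inhibitor of growth.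

Compound 4 (`O=C(/C(=C\c1c[nH]c2ccccc12)Sc1ccc(Br)cc1)c1ccc(Br)cc1`) has not yet been measured. It differs from compound 3 by a single exchange: 1H-indol-3-yl in place of 4-bromo-3-hydroxyphenyl on a double-bonded chain carbon bound to a double-bonded chain carbon.

Among the compounds with values here, only one measured step links two close relatives: no change at the digits printed from compound 2 to compound 3 (within the scatter). That step is hydroxy in place of hydrogen on an aromatic carbon, so it says little about exchanging a whole group. The nearest guide is compound 1, which also carries 1H-indol-3-yl and reads 10000 nM. Compound 1 differs from compound 4 elsewhere too, so the data cannot show how much of its higher number belongs to this group. A moderate rise in this assay is therefore expected, pointing to a weaker inhibitor of growth but stopping short of the number for compound 1.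

The expected change is a 3.0-fold higher number from compound 3 to compound 4 (0.48 log units; beyond the scatter). Compound 4 is estimated at 3000 nM, with an expected range from 800 nM to 10000 nM.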

Compound 4, concentration for 50% growth inhibition: 1000 nM
Compound 4: middle estimate off by 3.0-fold (0.48 log units), on the high side; the measured number falls inside the stated range.
By their numbers in this assay, from the lowest: compounds 2, 3 and 4 (each within the scatter of the next); then compound 1.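

In this assay, the exchange at this double-bonded chain carbon gives no change at the digits printed from compound 3 to compound 4 (within the scatter), and the exchange from the simpler 4-bromophenyl gives no change at the digits printed from compound 2 to compound 4 (within the scatter), so 1H-indol-3-yl, with its two rings, reads level with both single-ring groups in this place. The high number of compound 1 therefore cannot be laid on 1H-indol-3-yl, since the pair that carries this group on both sides shows a 10-fold lower number from compound 1 to compound 4 (1.00 log units; beyond the scatter), and that step is bromo in place of methyl on an aromatic carbon. No measurement at hand explains either result.

Going by these compounds, it remains open how far this tolerance extends, since a carboxylic acid, an amine or a longer chain on this double-bonded chain carbon could read quite differently from the three ring groups seen so far. On these data alone, the exchange of methyl for bromo also rests on a single pair, so whether it would give a similar step alongside 4-bromophenyl or 4-bromo-3-hydroxyphenyl is unknown.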